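A few compounds are considered here, and "the series" means these few. Any claim that something is new, unique, unknown or untested is made for them only; others in the source may bear on it.

Measured so far:
compound 1 `CC1(c2cc(NC(=O)Cn3nnc(-c4ccccc4)n3)n(C3CCCCC3)n2)CC1`, > 10%
compound 2 `Cc1cc(NC(=O)Cn2nnc(-c3cccc(Cl)c3)n2)n(C2CCCCC2)n1`, 89%.

The value shown for compound 1 in an assay on HEK293 cells for activation of Kir3.1/Kir3.2 (Homo sapiens), read by thallium flux (a lower number here means a smaller maximal response, a higher number a larger maximal response), is a limit of the assay and not a number: the limit of > 10% in this assay, at which 1 of the 2 values shown sits. Among the measured compounds shown here, compound 2 is therefore the only compound with an actual number in this assay, where compound 2 gives 89%. For the measured compounds named here, the one further value shown, that of compound 1, is a limit. Compound 3 `Cc1ccc(-c2nnn(CC(=O)Nc3cc(C)nn3C3CCCCC3)n2)cc1` has not yet been measured in this assay. It differs from compound 2 by 4-methylphenyl in place of 3-chlorophenyl on an aromatic carbon. Going by the values given here, no step between measured compounds is available, so the effect of this change is not anchored by any measured pair; as both groups are a six-membered aromatic ring of carbon only, a step in this assay of modest size is expected, more likely downward than upward, and possibly none beyond the scatter. For compound 3 the expected value is 75%, with a range from 40% to 100%. The expected step of a number 14 percentage points lower from compound 2 to compound 3 (beyond the scatter) is a small loss.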

Compound 3, largest response reached (Emax), in percent of the reference or control that the assay uses: 86%
Compound 3: middle estimate off by 11 percentage points, on the low side, and the stated range covers the measured number.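

In this assay, among the compounds shown here, the first measured step on the aromatic carbon of the five-membered aromatic ring with 4 nitrogen is a number 3 percentage points lower from compound 2 to compound 3 (within the scatter) and gives a first reading of this position. 3-chlorophenyl and 4-methylphenyl give maximal responses within the scatter of each other, so both groups are accepted here, though this reading rests on one pair only. No measured property available here bears on this step.

In this assay compound 1 gives > 10% as a limit and not a number, and its steps to the other compounds cannot be read. Still open, from the compounds shown here alone, is whether the maximal response holds when a pyridine ring or a cyclohexyl group stands at this position, or when the phenyl ring carries a carboxylic acid or a dimethylamino group.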